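From compound 3 to compound 4: hydroxy to cyano

The source may report more compounds than this note shows. Statements on the series, on what has been measured and on what is new or still open speak of the compounds shown alone.

Measured compounds in an ADME assay on CEMx174 cells (Homo sapiens) for cytotoxicity; a higher number here means that more compound is tolerated, a lower number that less compound is tolerated:
- compound 1 `CC1=C(C(=O)O)C(c2cccc(O)c2)NC(=O)N1` gives > 10000 nM as a limit
- compound 2 `CCCC1=C(C(=O)OCC2CCCCC2)C(c2cccc(O)c2)NC(=O)N1` gives > 10000 nM as a limit
- compound 3 `CCC1=C(C(=O)OCC2CCCCC2)C(c2ccc(O)cc2)NC(=O)N1` gives > 10000 nM as a limit

Compound 3 has no number in this assay and stands only at a limit (> 10000 nM). Among the measured compounds shown here, the whole set sits in the same place (the limit of > 10000 nM in this assay, at which 3 of the 3 values shown sit), and no two measured compounds differ in one place alone. Compound 4 (`CCC1=C(C(=O)OCC2CCCCC2)C(c2ccc(C#N)cc2)NC(=O)N1`) carries cyano in place of hydroxy on an aromatic carbon, para to a large group (cyano in place of hydroxy on an aromatic carbon). That change, 4-hydroxyphenyl to 4-cyanophenyl, has not been measured anywhere in this set, so no direction can be argued from the data. No step beyond the scatter is expected (a number no higher from compound 3 to compound 4 (the limit leaves the size open)). This expectation rests on the limit of compound 3 (> 10000 nM). The estimated value for compound 4 is 10000 nM with an expected range from 4000 nM to 25000 nM and the assay is expected to report only a limit again.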

Compound 4, half-maximal cytotoxic concentration: > 10000 nM
Compound 4 was reported as a limit; the forecaster's own chance of this, stated with the estimate: 80%; the middle value lies on the limit itself.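

In this assay, compound 4 gives > 10000 nM, a limit, and compound 3 also stands only at a limit, so no step can be read between them. The compounds shown leave open whether 4-hydroxyphenyl to 4-cyanophenyl changes the half-maximal cytotoxic concentration at all, and where any compound's actual value lies.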